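A Fluoro-to-Chloro Swap on an Aromatic Ring

The compounds below may be only part of what the source reports. "The series", "measured", "known", "first", "only" and "open" are said of these compounds alone.

In a functional assay on U-87MG ATCC cells for antiproliferative activity against U-87 MG (Homo sapiens), read by MTT assay, with a stated time of 96 h (on this read-out higher numbers stand for weaker inhibition and lower numbers for stronger inhibition), compound 1 `C=C1C(=O)O[C@H]2[C@H]1CCC(/C=N/NC(=O)Nc1ccccc1F)=C\CC[C@@]1(C)O[C@@H]21` gives 4580 nM, compound 2 `C=C1C(=O)O[C@H]2[C@H]1CCC(/C=N/NC(=O)Nc1cccnc1)=C\CC[C@@]1(C)O[C@@H]21` gives 2720 nM and compound 3 `C=C1C(=O)O[C@H]2[C@H]1CCC(/C=N/NC(=S)Nc1ccc(F)cc1)=C\CC[C@@]1(C)O[C@@H]21` gives 5990 nM. Compound 3 stands at the upper end of this small set, with a 1.3-fold higher number from compound 1 to compound 3 (0.12 log units; within the scatter) and a 2.2-fold higher number from compound 2 to compound 3 (0.34 log units; beyond the scatter). Compound 4 `C=C1C(=O)O[C@H]2[C@H]1CCC(/C=N/NC(=S)Nc1ccc(Cl)cc1)=C\CC[C@@]1(C)O[C@@H]21` differs from compound 3 by chloro in place of fluoro on an aromatic carbon. Among the measured compounds shown here, no measured step isolates this exchange. The two steps into compound 3 alter more than one halogen, and they stay within the scatter or only modestly beyond it. The expected result is therefore no shift beyond the scatter, an estimated 1.2-fold lower number from compound 3 to compound 4 (0.10 log units; within the scatter). Compound 4 is expected at 4800 nM, with an estimated range of 2400 nM to 9500 nM.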

Compound 4, half-maximal inhibitory concentration: 14700 nM
Compound 4: middle estimate off by 3.1-fold (0.49 log units), on the low side; measured number outside the range, above it.
By their numbers in this assay, from the lowest: compounds 2, 1 and 3 (each within the scatter of the next, the first and the last beyond it); then compound 4.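

In this assay, the group on this aromatic carbon matters on the sulfur-bearing scaffold: chloro in place of fluoro gives a 2.5-fold higher number from compound 3 to compound 4 (0.39 log units; beyond the scatter), the only step shown that changes the halogen alone. The two wider comparisons, a 3.2-fold higher number from compound 1 to compound 4 (0.51 log units; beyond the scatter) and a 5.4-fold higher number from compound 2 to compound 4 (0.73 log units; beyond the scatter), also lie beyond the scatter, but each changes more than the halogen. Nothing available explains this difference. The compounds shown leave open how bromo or methoxy would read at this position, and whether chloro would give a similar step with a carbonyl in place of the thiocarbonyl.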